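Compound 3 to compound 4: a new group on the carbonyl

The compounds below may be only part of what the source reports. "The series", "measured", "known", "first", "only" and "open" are said of these compounds alone.

In a functional assay on MCF7 cells (Homo sapiens) for inhibition, read by MTT assay (on this read-out higher numbers stand for weaker inhibition and lower numbers for stronger inhibition), compound 3 `COc1cc2ncnc(Nc3ccc(NC(=O)c4ccccc4Cl)cc3)c2cc1OC` gives 36000 nM, and compound 1 `COc1cc2ncnc(Nc3ccc(NC(=O)c4ccccc4C)cc3)c2cc1OC` gives 21000 nM. The step of a 1.7-fold higher number from compound 1 to compound 3 (0.23 log units; within the scatter) lies within the scatter, so these two cannot be told apart. Compound 2 `COc1cc2ncnc(Nc3ccc(NC(=O)c4ccc(C(C)(C)C)cc4)cc3)c2cc1OC` reads > 100000 nM, which is a limit of the assay and not a number. Compound 4 `COc1cc2ncnc(Nc3ccc(NC(=O)c4ccc(C(F)(F)F)cc4)cc3)c2cc1OC` has 4-(trifluoromethyl)phenyl in place of 2-chlorophenyl on a carbonyl carbon. The nearest guide is the 4-(tert-butyl)phenyl group of compound 2, seen in an at least 4.7-fold higher number from compound 1 to compound 2 (0.67 log units; beyond the scatter) and an at least 2.7-fold lower number from compound 2 to compound 3 (0.44 log units; beyond the scatter), both beyond the scatter and both tying that group to the higher number. The expected step, a 1.7-fold higher number from compound 3 to compound 4 (0.22 log units; within the scatter), points the same way but stays modest. Compound 4 is estimated at 60000 nM, with an expected range from 25000 nM to 140000 nM.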

Compound 4, half-maximal inhibitory concentration: > 100000 nM
Compound 4: no number, only a limit (the forecaster's own chance of this, stated with the estimate: 30%); middle value at least 1.6-fold (0.22 log units) from the limit.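

Moving to 4-(trifluoromethyl)phenyl on the carbonyl shows as an at least 2.7-fold higher number from compound 3 to compound 4 (0.44 log units; beyond the scatter) and as an at least 4.7-fold higher number from compound 1 to compound 4 (0.67 log units; beyond the scatter) in this assay. Both 4-substituted groups, 4-(tert-butyl)phenyl in compound 2 and 4-(trifluoromethyl)phenyl in compound 4, now go with the weakest reading, while the 2-substituted groups of compound 1 and compound 3 still give numbers. The step between compound 2 and compound 4 cannot be read, so these two groups cannot be ranked: the limit of > 100000 nM in this assay, at which 2 of the 4 values shown sit.

Still open, going by these compounds, is whether the substituent itself or its place on the ring matters. A 2-(trifluoromethyl)phenyl or a 4-aminophenyl group on the carbonyl would help to separate the two.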